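A few compounds are considered here, and "the series" means these few. Any claim that something is new, unique, unknown or untested is made for them only; others in the source may bear on it.

Measured compounds in a functional assay on PC-3 cells (Homo sapiens) for inhibition, read by MTT assay, with a stated time of 48 h; on this read-out lower numbers stand for stronger inhibition and higher numbers for weaker inhibition: compound 1 `C=C1CC[C@@H]2[C@](C)(CO)[C@H](O)CC[C@@]2(C)[C@@H]1CC(Sc1ccc(C)cc1)C1=CCOC1=O` gives 29000 nM; compound 2 `C=C1CC[C@@H]2[C@](C)(CO)[C@H](O)CC[C@@]2(C)[C@@H]1CC(Sc1ccccc1)C1=CCOC1=O` gives 14000 nM; compound 3 `C=C1CC[C@@H]2[C@](C)(CO)[C@H](O)CC[C@@]2(C)[C@@H]1C/C=C1/C(=O)OC[C@H]1OC(=O)CSc1ccc([N+](=O)[O-])cc1` gives 17000 nM.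

Compound 3 stands second highest of the three numbers. Its gap to compound 2, the nearest, and to compound 1, the furthest, both lie within the usual scatter, so no order among the three can be read from these values.

Compound 4 `C=C1CC[C@@H]2[C@](C)(CO)[C@H](O)CC[C@@]2(C)[C@@H]1C/C=C1/C(=O)OC[C@H]1OC(=O)CSc1ccc(F)cc1` differs from compound 3 in one place: fluoro in place of nitro on an aromatic carbon.

Among the measured compounds shown here, only one measured step concerns a substituent on the aromatic ring of the sulfanyl group, a 2.1-fold lower number from compound 1 to compound 2 (0.32 log units; beyond the scatter). That step is modest, and in compounds 1 and 2 the sulfanyl aryl group is attached to a different part of the shared core than in compounds 3 and 4; neither nitro nor fluoro appears among the measured compounds. The exchange of nitro for fluoro is therefore expected to give no step beyond the scatter, a 1.1-fold lower number from compound 3 to compound 4 (0.05 log units; within the scatter).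

Compound 4 is estimated at 15000 nM in this assay, with a range from 6000 nM to 40000 nM.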

Compound 4, half-maximal inhibitory concentration: 14000 nM
Compound 4: the middle estimate sits 1.1-fold (0.03 log units) above what was measured, and the stated range covers the measured number.
By their numbers in this assay, from the lowest: compounds 2, 4, 3 and 1 (each within the scatter of the next, the first and the last beyond it).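

In this assay, fluoro in place of nitro on the aromatic carbon para to a large group gives a 1.2-fold lower number from compound 3 to compound 4 (0.08 log units; within the scatter). This position therefore accepts a swap from nitro, with 3 heavy atoms and 2 hydrogen-bond acceptors, to fluoro, with 1 heavy atom and no hydrogen-bond acceptor, without a step beyond the scatter; compound 3 alone could not show this. No measurement at hand explains why the two groups read alike.

The compounds shown leave open whether the position is as tolerant of a group of another kind, such as an amine or a carboxylic acid, since nitro and fluoro are the only two groups compared here. They also leave open whether a longer chain in place of the ((4-fluorophenyl)sulfanyl)methyl group would keep the reading of compound 4.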